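Amide to urea on the shared core: expected growth inhibition

A few compounds are considered here, and "the series" means these few. Any claim that something is new, unique, unknown or untested is made for them only; others in the source may bear on it.

Compound 1 `COc1cc(-c2nn(-c3cccc(NC(=O)c4ccc(Cl)c(C(F)(F)F)c4)c3)cc2-c2ccncc2)ccc1Cl` gives 3380 nM in a functional assay on HT-29 cells (Homo sapiens) for inhibition, read by sulforhodamine B assay, with a stated time of 48 h (a lower number here means a stronger inhibitor of growth, a higher number a weaker inhibitor of growth), the highest of the two numbers measured; compound 2 `O=C(Nc1cccc(-n2cc(-c3ccncc3)c(-c3ccc(Cl)c(O)c3)n2)c1)Nc1cc(C(F)(F)F)cc(C(F)(F)F)c1` gives 746 nM, a gap beyond the scatter. Compound 3 `COc1cc(-c2nn(-c3cccc(NC(=O)Nc4cccc(C(F)(F)F)c4)c3)cc2-c2ccncc2)ccc1Cl` is not yet measured. It differs from compound 1 by (3-(trifluoromethyl)phenyl)amino in place of 4-chloro-3-(trifluoromethyl)phenyl on a carbonyl carbon. Among the compounds with values here, no measured pair isolates this change; compound 2 carries a urea but also differs elsewhere. The step from compound 1 to compound 3 is expected to lower the number, a 2.8-fold lower number from compound 1 to compound 3 (0.45 log units; beyond the scatter), modestly beyond the scatter. Compound 3 is estimated at 1200 nM, within 400 nM to 3500 nM.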

Compound 3, concentration for 50% growth inhibition: 748 nM
Compound 3: the middle estimate sits 1.6-fold (0.21 log units) above what was measured; low and high end bracket the measured number.
By their numbers in this assay, from the lowest: compounds 2 and 3 (each within the scatter of the next); then compound 1.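

In this assay, (3-(trifluoromethyl)phenyl)amino in place of 4-chloro-3-(trifluoromethyl)phenyl on the carbonyl carbon gives a 4.5-fold lower number from compound 1 to compound 3 (0.66 log units; beyond the scatter), the first step read at this position. The change turns the amide of compound 1 into the urea of compound 3 and also removes the ring chlorine, and the two parts remain unseparated. No measurement on hand accounts for the step. Open, on these data alone, is whether a urea keeping the 4-chloro substituent, or one carrying a nitrile in place of the trifluoromethyl, would give a similar number.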